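Shortening the Thioether Chain of Compound 3 by One Carbon

A few compounds are considered here, and "the series" means these few. Any claim that something is new, unique, unknown or untested is made for them only; others in the source may bear on it.

Measured compounds and their values:
compound 1 `CCCCSCSCC1C2CCC(O2)C1C/C=C\CCCC(=O)O`: 700 nM
compound 2 `CCCCCCCSC1C2CCC(O2)C1C/C=C\CCCC(=O)O`: 230000 nM; 35000 nM (2 entries)
compound 3 `CCCCCCCSCC1C2CCC(O2)C1C/C=C\CCCC(=O)O`: 42000 nM

Going by the values given here, in a functional assay on a cell-free system (plasma) for inhibition of thromboxane A2 receptor (Homo sapiens) (on this read-out lower numbers stand for stronger inhibition and higher numbers for weaker inhibition), compound 3 stands highest of the two compounds that have a single number, and the one measured step, a 60-fold higher number from compound 1 to compound 3 (1.78 log units; beyond the scatter), is large. Compound 2 has two entries that spread widely, as shown by the several entries of compound 2 in this assay, 230000 nM; 35000 nM (2 entries), so it gives no firm anchor. Compound 4 `CC/C=C/CCSCC1C2CCC(O2)C1C/C=C\CCCC(=O)O` differs from compound 3 by but-1-en-1-yl in place of pentyl on a saturated chain carbon, two bonds along the chain from a sulfur. Among the compounds with values here, no measured step covers such a change, because the only step measured concerns a different exchange. The step of a 1.1-fold lower number from compound 3 to compound 4 (0.02 log units; within the scatter) is therefore expected to stay within the scatter. Compound 4 is estimated at 40000 nM, with a range from 10000 nM to 160000 nM.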

Compound 4, half-maximal inhibitory concentration: 700 nM
For compound 4 the middle estimate is 57-fold (1.76 log units) above the measured one; measured number below the stated range.
By their numbers in this assay, from the lowest: compounds 1 and 4 (each within the scatter of the next); then compound 3.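

In this assay, a small change at the far end of the thioether chain decides the result: a 60-fold lower number from compound 3 to compound 4 (1.78 log units; beyond the scatter), with but-1-en-1-yl in place of pentyl. Butylsulfanyl is also not required for a number of this size, as pent-2-en-1-yl in its place gives no change at the digits printed from compound 1 to compound 4 (within the scatter). Nothing measured here explains why this exchange has so large an effect.

The compounds shown leave open whether the double bond or the shorter chain carries the step. Butyl in the same place, a saturated chain of the same length, would separate the two.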